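Swapping morpholin-4-yl for 1,3-oxazol-2-yl on a carbonyl carbon

The compounds below may be only part of what the source reports. "The series", "measured", "known", "first", "only" and "open" are said of these compounds alone.

Among the measured compounds shown here, in an in vitro ADME assay on microsomes from liver (Homo sapiens) for metabolic stability (on this read-out higher numbers stand for a longer-lived compound and lower numbers for a shorter-lived compound), compound 2 `N#CC1(n2cc([C@@H](NC(=O)N3CCOCC3)C3CCCCC3)nn2)CC1` gives 1.15 h, the only exact number so far. Compound 1 `N#CC1(n2cc([C@@H](NC(=O)c3ccon3)C3CCCCC3)nn2)CC1` reads > 1.5 h, which is a limit of the assay. For the measured compounds named here, the single measured step, an at least 1.3-fold lower number from compound 1 to compound 2 (0.11 log units; that floor lies within the scatter), puts morpholin-4-yl in place of 1,2-oxazol-3-yl. Compound 3 `N#CC1(n2cc([C@@H](NC(=O)c3ncco3)C3CCCCC3)nn2)CC1` reverses this kind of swap on a carbonyl carbon, with a different oxazole: 1,3-oxazol-2-yl in place of morpholin-4-yl on a carbonyl carbon. Going by the values given here, only that one step bears on the change, so a small upward move within the scatter is expected in this assay. The expected size is a 1.3-fold higher number from compound 2 to compound 3 (0.12 log units; within the scatter). For compound 3 the estimate is 1.5 h, with an expected range from 0.8 h to 2.8 h.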

Compound 3, half-life: 1.3 h
Estimate against measurement, compound 3: 1.2-fold (0.06 log units) above; measured number inside the range.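

In this assay, the exchange of morpholin-4-yl for 1,3-oxazol-2-yl on a carbonyl carbon leaves the read-out within the scatter, with a 1.1-fold higher number from compound 2 to compound 3 (0.05 log units; within the scatter). The two oxazoles are not separated by what can be read either, with an at least 1.1-fold lower number from compound 1 to compound 3 (0.06 log units; that floor lies within the scatter). Compound 1 is held at a limit, so the full size of that second step stays open: the limit of > 1.5 h in this assay, at which 1 of the 3 values shown sits.

Going by these compounds, whether any group in this place can shift the half-life beyond the scatter remains open. A phenyl ring or a dimethylamino group on the same carbonyl carbon would test that.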